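A few compounds are considered here, and "the series" means these few. Any claim that something is new, unique, unknown or untested is made for them only; others in the source may bear on it.

Working notes on the series in a functional assay on the whole organism (strain Wistar) for inhibition, with Rattus norvegicus as the target, read by paw edema, with a stated time of 30 min, at a dose of 10 mg/kg by the intraperitoneal route; on this read-out lower numbers stand for less inhibition and higher numbers for more inhibition at the one dose given (going by the name of the read-out). Compound 1 `O=C(N/N=C/c1ccccc1)c1cccnc1Nc1cccc(C(F)(F)F)c1` gives 60.4% in this assay. Compound 2 `COc1ccc(/C=N/NC(=O)c2cccnc2Nc2cccc(C(F)(F)F)c2)cc1OC` gives 60.1% in this assay. Going by the values given here, the one step measured so far, a number 0.3 percentage points lower from compound 1 to compound 2 (within the scatter), is within the scatter, so the two numbers cannot be told apart. Among the compounds with values here, compound 2 therefore stands at the same level as compound 1, the only other measured compound, with nothing in the numbers to set it apart.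

Compound 3 `COc1cc(/C=N/NC(=O)c2cccnc2Nc2cccc(C(F)(F)F)c2)cc(OC)c1OC` is the next member. Relative to compound 2 the change is methoxy in place of hydrogen on an aromatic carbon. Within the data shown here, the only measured step that bears on this is a number 0.3 percentage points lower from compound 1 to compound 2 (within the scatter), in which two methoxy groups entered the same six-membered aromatic ring of carbon only without a change beyond the scatter. A third methoxy group on that ring is a smaller change than that step, and no other data speak to it, so for compound 3 the expected step is a number 0.1 percentage points lower from compound 2 to compound 3 (within the scatter), none beyond the scatter in either direction. In this assay compound 3 is thus estimated at 60%, with a range from 48% to 70%.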

Compound 3, a percentage reported as inhibition, in the whole organism at one dose (the size of the read-out at that dose, not a potency): 55.9%
Compound 3: the middle estimate sits 4.1 percentage points above what was measured, and the stated range covers the measured number.
By their numbers in this assay, from the lowest: compounds 3, 2 and 1 (each within the scatter of the next).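

In this assay, the methoxy group that enters on the aromatic carbon ortho to a methoxy group and meta to a large group gives a number 4.2 percentage points lower from compound 2 to compound 3 (within the scatter), so compound 2 and compound 3 cannot be told apart at the one dose given. Unlike the earlier step, which replaced phenyl with 3,4-dimethoxyphenyl as a whole, this one adds a single methoxy group in place of hydrogen at one position, and the six-membered aromatic ring of carbon only carries this further group without a change beyond the scatter. No measurement shown gives any information on what lies behind this result.

All the ring substituents in the compounds shown are methoxy groups, so it remains open whether an amine, a carboxylic acid or a longer alkoxy chain such as butoxy at this position would move the read-out beyond the scatter. From the compounds shown here alone, compounds 1, 2 and 3 also share the core with its trifluoromethyl group, so how far that part contributes to the level of inhibition, and how the compounds compare at other doses, remains open as well.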